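This account rests on a few compounds, and the source may have more. Where it says the series, first, only, none or still open, it means among the compounds named here.

Measured in a functional assay on KB 3-1 cells (Homo sapiens) for cytotoxicity, read by MTT assay, with a stated time of 72 h; on this read-out lower numbers stand for stronger inhibition and higher numbers for weaker inhibition:
- Compound 1 `O=C1Nc2ccccc2/C1=N/NC(=S)Nc1ccc(F)cc1`: 14200 nM
- Compound 2 `O=C1Nc2ccccc2/C1=N/NC(=S)Nc1ccc(C(=O)O)cc1`: > 50000 nM, a limit of the assay and not a number
- Compound 3 `O=C1Nc2ccccc2/C1=N/NC(=S)Nc1ccc(Oc2ccccc2)cc1`: 5720 nM

Among these, compound 3 gives the lowest number, at 5720 nM, and compound 1 is its nearest neighbour. The next compound, compound 4 `CC(C)(C)c1ccc(NC(=S)N/N=C2\C(=O)Nc3ccccc32)cc1`, has tert-butyl in place of phenoxy on an aromatic carbon.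

Going by the values given here, no measured step makes this exact swap, so the guidance is indirect. The closest is a 2.5-fold lower number from compound 1 to compound 3 (0.39 log units; beyond the scatter), a modest change from replacing fluoro with phenoxy. The larger steps, an at least 3.5-fold higher number from compound 1 to compound 2 (0.54 log units; beyond the scatter) and an at least 8.7-fold lower number from compound 2 to compound 3 (0.94 log units; beyond the scatter), both involve carboxy and rest on the limit for compound 2, so they say little about tert-butyl. Neither group in the new swap carries a net charge, so a small shift seems likelier than a large one. It would probably lean towards a higher number in this assay, perhaps staying within the usual scatter. The expected change is a 1.2-fold higher number from compound 3 to compound 4 (0.09 log units; within the scatter). For compound 4 the estimated value is 7000 nM, with an expected range from 3000 nM to 16000 nM.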

Compound 4, half-maximal inhibitory concentration: 8130 nM
The estimate for compound 4 lay 1.2-fold (0.06 log units) below the measured number; the measured number falls inside the stated range.
By their numbers in this assay, from the lowest: compounds 3, 4 and 1 (each within the scatter of the next, the first and the last beyond it). At a limit, above all of these: compound 2.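

In this assay, putting tert-butyl in place of phenoxy gives a 1.4-fold higher number from compound 3 to compound 4 (0.15 log units; within the scatter), so this position does not need a ring to keep the number close to that of compound 3. Tert-butyl in place of fluoro gives a 1.7-fold lower number from compound 1 to compound 4 (0.24 log units; within the scatter), so compound 4 cannot be told apart from compound 1 either, even though compound 1 and compound 3 lie beyond the scatter of each other. Only compound 2, with carboxy, stands clearly apart, with an at least 6.1-fold lower number from compound 2 to compound 4 (0.78 log units; beyond the scatter) and a value for compound 2 that is a limit of the assay and not a number: the limit of > 50000 nM in this assay, at which 1 of the 4 values shown sits.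

As far as these compounds go, whether an amine at this position would sit with compound 2 or with the groups that carry no net charge stays open. So does whether a longer chain would move the number beyond the scatter of compound 3.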